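From 2-Methylphenyl to 4-Chlorophenyl in Compound 3

The compounds below may be only part of what the source reports. "The series", "measured", "known", "first", "only" and "open" are said of these compounds alone.

In a functional assay on MKN-45 cells (Homo sapiens) for inhibition, read by CCK-8 assay, with a stated time of 24 h (a lower number here means a stronger inhibitor, a higher number a weaker inhibitor), compound 1 `O=C1Nc2ccc(F)cc2C1=Cc1ccc(-c2cn(-c3ccccc3)nn2)cc1` gives 11100 nM and compound 2 `Cc1ccccc1-n1cc(-c2ccc(C=C3C(=O)Nc4ccc(F)cc43)cc2)nn1` gives 7210 nM, two values within the scatter of each other. Among the measured compounds shown here, the only measured step, a 1.5-fold lower number from compound 1 to compound 2 (0.19 log units; within the scatter), places a methyl in place of hydrogen on an aromatic carbon. Compound 3 `O=C1Nc2ccc(F)cc2C1=Cc1ccc(-c2cn(-c3ccc(Cl)cc3)nn2)cc1` differs from compound 2 by 4-chlorophenyl in place of 2-methylphenyl on an aromatic nitrogen. For the measured compounds named here, no chlorine-bearing compound has been measured yet, so only that one small step bears on this change. In this assay, the expected change is nothing beyond the scatter, an estimated 1.1-fold higher number from compound 2 to compound 3 (0.05 log units; within the scatter). Compound 3 is expected at 8000 nM, within an estimated range of 3000 nM to 20000 nM.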

Compound 3, half-maximal inhibitory concentration: 15800 nM
Estimate against measurement, compound 3: 2.0-fold (0.30 log units) below, and the stated range covers the measured number.
By their numbers in this assay, from the lowest: compounds 2, 1 and 3 (each within the scatter of the next, the first and the last beyond it).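

In this assay, among the compounds shown here, the swap on the aromatic nitrogen gives a 2.2-fold higher number from compound 2 to compound 3 (0.34 log units; beyond the scatter) and is the first step here to pass the scatter. Chloro in place of hydrogen alone gives a 1.4-fold higher number from compound 1 to compound 3 (0.15 log units; within the scatter) and stays within it, so the clear gap appears only between the two substituted phenyl groups, 2-methylphenyl and 4-chlorophenyl. Nothing measured here offers a reason for that gap. Still open, going by these compounds, is whether an amine, a carboxylic acid or a methoxy group on this phenyl ring would move the number any further.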